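A few compounds are considered here, and "the series" means these few. Any claim that something is new, unique, unknown or untested is made for them only; others in the source may bear on it.

Measured in an ADME assay on microsomes from liver (Rattus norvegicus) for metabolic stability, with a stated time of 10 min; on this read-out lower numbers stand for a less stable compound and higher numbers for a more stable compound:

Compound 1, `CCS(=O)(=O)NC(=O)c1ccc(Nc2nc(NC3(c4ccc(Cl)cc4)CC3)nc(OCC(F)(F)F)n2)cc1`: 85%
Compound 2, `CC(C)(C)CNCCS(=O)(=O)NC(=O)c1ccc(Nc2nc(NC3(c4ccc(Cl)cc4)CC3)nc(OCC(F)(F)F)n2)cc1`: 90%
Compound 3, `O=C(NS(=O)(=O)C1CC1)c1ccc(Nc2nc(NC3(c4ccc(Cl)cc4)CC3)nc(OCC(F)(F)F)n2)cc1`: 85%

Compound 3 stands level with compound 1 at the digits shown, and the two together give the lowest of the three numbers in this assay; the nearest neighbour of compound 3 is compound 1, with no change at the digits printed from compound 1 to compound 3 (within the scatter), and the furthest is compound 2, with a number 5 percentage points lower from compound 2 to compound 3 (within the scatter). For the measured compounds named here, all three values sit close to one another, so on this read-out the series so far is flat.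

The next compound, compound 4, `CN(C)S(=O)(=O)NC(=O)c1ccc(Nc2nc(NC3(c4ccc(Cl)cc4)CC3)nc(OCC(F)(F)F)n2)cc1`, carries a change on the same part of the molecule: dimethylamino in place of cyclopropyl on a sulfonyl sulfur. The two steps that bear on it are those that exchanged the group on that sulfonyl sulfur: no change at the digits printed from compound 1 to compound 3 (within the scatter) and a number 5 percentage points lower from compound 2 to compound 3 (within the scatter), both inside the scatter. Three different groups on that sulfur have left the read-out unmoved, and nothing in the set points to a step beyond the scatter for a fourth one.

The expected step in this assay is therefore no change at the digits printed from compound 3 to compound 4 (within the scatter), with no movement beyond the scatter anticipated. The estimate for compound 4 in this assay is 85%, within a range from 74% to 94%.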

Compound 4, percent of the compound remaining: 76%
The estimate for compound 4 lay 9 percentage points above the measured number; the range from low to high includes it.
By their numbers in this assay, from the lowest: compounds 4, 1, 3 and 2 (each within the scatter of the next, the first and the last beyond it).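

In this assay, for the compounds shown here, dimethylamino on the sulfonyl sulfur gives the first step in the set that lies beyond the scatter (a number 14 percentage points lower from compound 2 to compound 4 (beyond the scatter)), though it is only modest. The other two comparisons stay within the scatter (a number 9 percentage points lower from compound 3 to compound 4 (within the scatter); a number 9 percentage points lower from compound 1 to compound 4 (within the scatter)), so compound 4 separates from compound 2 alone, and the exchange of cyclopropyl or ethyl for dimethylamino cannot be read as a real change on its own. This group is therefore the first at this position to separate from any other, but nothing available explains that separation.

The compounds shown do not tell whether the separation follows the nitrogen bound directly to the sulfonyl sulfur or belongs to the 2-(neopentylamino)ethyl group of compound 2, and a ring amine such as pyrrolidine or morpholine on that sulfur would help to separate these readings. A plain longer chain such as n-butyl, with no amine in it, would likewise show whether compound 2 owes its place in the set to chain length or to the amine within the chain.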